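The compounds below may be only part of what the source reports. "The series", "measured", "known", "first", "only" and "open" are said of these compounds alone.

Compound 1, `CCc1c(OC)nc2nc(-c3nc(C)cs3)cn2c1C`, was tested in a functional assay on the whole organism with Rattus norvegicus as the target; on this read-out higher numbers stand for an effect only at larger amounts of compound and lower numbers for an effect already at smaller amounts. In this assay compound 1 gives > 50 mg/kg, which is a limit of the assay and not a number. Compound 2, `C=CCc1c(OC)nc2nc(-c3nc(C)cs3)cn2c1C`, differs from compound 1 by vinyl in place of methyl on a saturated chain carbon bound to an aromatic carbon. In this assay compound 2 gives > 50 mg/kg, again a limit rather than a number. The step that the two limits leave unreadable from compound 1 to compound 2 therefore cannot be read. All that is known of where compound 1 stands is the limit of > 50 mg/kg in this assay, at which 2 of the 2 values shown sit. Compound 3, `CCc1c(OC)nc2nc(-c3n[nH]c(C)n3)cn2c1C`, differs from compound 1 by 5-methyl-1H-1,2,4-triazol-3-yl in place of 4-methyl-1,3-thiazol-2-yl on an aromatic carbon. Among the compounds with values here, no measured step touches this change, and the one step that was measured has no readable size. The expected step in this assay is a number no higher from compound 1 to compound 3 (the limit leaves the size open). Compound 3 is therefore estimated at 50 mg/kg, with a range from 15 mg/kg to 150 mg/kg.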

Compound 3, minimum effective dose: > 50 mg/kg
Compound 3: only a limit was reported (the forecaster's own chance of this, stated with the estimate: 70%); the middle value lies on the limit itself.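

In this assay compound 3 gives > 50 mg/kg, a limit and not a number, so the step from compound 1 to compound 3 cannot be read. The compounds shown leave open whether exchanging 4-methyl-1,3-thiazol-2-yl for 5-methyl-1H-1,2,4-triazol-3-yl changes the effective dose, and all that is known is this: the limit of > 50 mg/kg in this assay, at which 3 of the 3 values shown sit.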